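This account rests on a few compounds, and the source may have more. Where it says the series, first, only, none or still open, it means among the compounds named here.

Compound 1 `O=C(Nc1ccc(NC2CCCCC2)cc1Cl)c1cc(Cl)ccc1O`: 68300 nM
Compound 2 `O=C(Nc1ccc(NCc2ccc(Cl)cc2)cc1Cl)c1cc(Cl)ccc1O`: 59700 nM

Going by the values given here, in an ADME assay on A549 cells (Homo sapiens) for cytotoxicity, read by resazurin assay, with a stated time of 48 h (on this read-out lower numbers stand for higher toxicity in this test and higher numbers for lower toxicity in this test), compound 2 gives 59700 nM, within the scatter of compound 1, the only other compound measured. Compound 3 `O=C(Nc1ccc(NCc2cc(F)cc(Cl)c2)cc1Cl)c1cc(Cl)ccc1O` is not yet measured. It carries 3-chloro-5-fluorophenyl in place of 4-chlorophenyl on a saturated chain carbon bound to a nitrogen on an aromatic ring. Among the compounds with values here, the one measured step, a 1.1-fold lower number from compound 1 to compound 2 (0.06 log units; within the scatter), changed the group on that nitrogen and stayed within the scatter. Within the data shown here, no measured step tests this exact swap, so no shift beyond the scatter is expected in this assay. The estimated step is a 1.1-fold lower number from compound 2 to compound 3 (0.04 log units; within the scatter). Compound 3 is expected at about 55000 nM, with an estimated range of 25000 nM to 110000 nM.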

Compound 3, half-maximal cytotoxic concentration: 11100 nM
Beside the measured number, compound 3's estimate is 5.0-fold (0.70 log units) above it; the measured number lies below the stated range.
By their numbers in this assay, from the lowest: compound 3; then compounds 2 and 1 (each within the scatter of the next).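

In this assay the group on this nitrogen can shift the number beyond the scatter: 3-chloro-5-fluorophenyl in place of 4-chlorophenyl gives a 5.4-fold lower number from compound 2 to compound 3 (0.73 log units; beyond the scatter) on a saturated chain carbon. Against the cyclohexyl compound the change gives a 6.2-fold lower number from compound 1 to compound 3 (0.79 log units; beyond the scatter) and so the ring's substituents separate compound 3, where the 4-chlorobenzyl of compound 2 did not separate from cyclohexyl. Nothing available explains this shift. Going by these compounds, the fluorine and the chlorine's new place changed together, so their shares remain unknown. A 3-chlorobenzyl or 3-fluorobenzyl group would pull them apart.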